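Urea and extended semicarbazide ends in one series

A few compounds are considered here, and "the series" means these few. Any claim that something is new, unique, unknown or untested is made for them only; others in the source may bear on it.

Measured in a functional assay on L1210 cells (Mus musculus) for inhibition, read by MTT assay, with a stated time of 72 h; a higher number here means a weaker inhibitor, a lower number a stronger inhibitor:
- compound 1 `COc1cc(NC(C)CCCNC(=O)NNC(=O)Nc2cccc(F)c2)c2ncccc2c1`: 108000 nM
- compound 2 `COc1cc(NC(C)CCCNC(=O)Nc2ccc(Cl)cc2)c2ncccc2c1`: 19000 nM

Of these two numbers, the lower belongs to compound 2, at 19000 nM. Next is compound 3 `COc1cc(NC(C)CCCNC(=O)NNC(=O)Nc2cccc(Cl)c2)c2ncccc2c1`, which differs from compound 2 as follows: ((3-chlorophenyl)carbamoyl)amino in place of 4-chlorophenyl on an amide-type nitrogen. In words, ((3-chlorophenyl)carbamoyl)amino stands in place of 4-chlorophenyl on an amide-type nitrogen. Among the measured compounds shown here, the only measured step bearing on this is a 5.7-fold lower number from compound 1 to compound 2 (0.75 log units; beyond the scatter). That step runs the opposite way, with 4-chlorophenyl in place of ((3-fluorophenyl)carbamoyl)amino on an amide-type nitrogen. A modest step of similar size towards a higher number is therefore expected in this assay. The data hold no measured exchange of chlorine for fluorine, and one step is a thin basis. The estimated step is a 4.5-fold higher number from compound 2 to compound 3 (0.65 log units; beyond the scatter). Compound 3 is estimated at 85000 nM, with an expected range of 30000 nM to 200000 nM.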

Compound 3, half-maximal inhibitory concentration: 27000 nM
The estimate for compound 3 lay 3.1-fold (0.50 log units) above the measured number; the measured number lies below the stated range.
By their numbers in this assay, from the lowest: compounds 2 and 3 (each within the scatter of the next); then compound 1.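

In this assay, the change on the amide-type nitrogen from 4-chlorophenyl to ((3-chlorophenyl)carbamoyl)amino gives a 1.4-fold higher number from compound 2 to compound 3 (0.15 log units; within the scatter), so the extended end as such does not set these two compounds apart. The earlier comparison, with a fluoro-bearing extended end, suggested a penalty for that end, but the halogen also counts: chloro in place of fluoro on an aromatic carbon gives a 4.0-fold lower number from compound 1 to compound 3 (0.60 log units; beyond the scatter). The size of the gap between the urea and extended ends therefore depends on the halogen carried by the extended end, and nothing available explains either step.

Going by these compounds, it remains open whether bromo or trifluoromethyl on the extended end would continue the step seen from fluoro to chloro. On these data alone, the effect of a longer chain between the urea and the shared core also remains open.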